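A Hydroxy Group Added to a Lactone Terpenoid Core

The source may report more compounds than this note shows. Statements on the series, on what has been measured and on what is new or still open speak of the compounds shown alone.

Compound 1, `C=C1CCCC2C1(C)CCC(C)C2(C)CCC1=CC(=O)OC1O`, gives 12.7 nM in an assay on isolated protein for inhibition of Polyunsaturated fatty acid 5-lipoxygenase (Homo sapiens), read by spectrophotometry, with a stated time of 10 min; on this read-out higher numbers stand for weaker inhibition and lower numbers for stronger inhibition.
Compound 2, `CC1=CCCC2C1(C)CCC(C)C2(C)CCC1=CC(=O)OC1O`, gives 14.4 nM in this assay.

Among the measured compounds shown here, of the two numbers so far, compound 1 has the lowest, but compound 2 sits within the usual scatter of it, so the two cannot be told apart on this assay. These two differ from each other at another place on the shared core, and that comparison tells nothing about what follows.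

Compound 3, `C=C1C(O)CCC2C1(C)CCC(C)C2(C)CCC1=CC(=O)OC1O`, has not yet been measured. It differs from compound 1 by hydroxy in place of hydrogen on a saturated ring carbon. No measured pair shows this change, so neither its size nor its direction can be read from the numbers shown, and a small step in either direction, or none beyond the scatter, seems most plausible.

For compound 3 the expected step is a 1.4-fold higher number from compound 1 to compound 3 (0.15 log units; within the scatter). Compound 3 is expected to give about 18 nM in this assay, within a range from 6 nM to 55 nM.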

Compound 3, half-maximal inhibitory concentration: 16.5 nM
The estimate for compound 3 lay 1.1-fold (0.04 log units) above the measured number; the measured number falls inside the stated range.
By their numbers in this assay, from the lowest: compounds 1, 2 and 3 (each within the scatter of the next).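

Putting hydroxy in place of hydrogen on this saturated ring carbon gives a 1.3-fold higher number from compound 1 to compound 3 (0.11 log units; within the scatter) in this assay, so the change cannot be told apart from no change at all. Among the compounds shown here, this is the first measured look at this position, and it shows that the position tolerates hydroxy on the core of compound 1 with no loss of inhibition beyond the scatter. Nothing available explains this result.

As far as these compounds go, it remains open whether a different group on this same carbon, such as a methoxy group, an amine or a carboxylic acid, would also leave the number within the scatter. From the compounds shown here alone, it is also open whether the same hydroxy would give a similarly small step on compound 2, which differs from compound 1 at another place on the shared core.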